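Swapping the aryl group on the hydrazone carbon

This account rests on a few compounds, and the source may have more. Where it says the series, first, only, none or still open, it means among the compounds named here.

Of the compounds shown here, two built on one shared core have been tested in a functional assay on HepG2 cells (Homo sapiens) for cytotoxicity, read by MTT assay, with a stated time of 48 h; on this read-out higher numbers stand for weaker inhibition and lower numbers for stronger inhibition. Compound 1 `O=C(CSc1nnc(-c2ccncc2)o1)N/N=C/c1ccc(F)cc1` gives 12300 nM in this assay and holds the lower of the two numbers, though the gap to its neighbour is within the scatter. Compound 2 `O=C(CSc1nnc(-c2ccncc2)o1)N/N=C/c1ccccc1[N+](=O)[O-]` gives 24700 nM; the step of a 2.0-fold higher number from compound 1 to compound 2 (0.30 log units; within the scatter) leaves the two compounds within the scatter of one another. Compound 3 `O=C(CSc1nnc(-c2ccncc2)o1)N/N=C/c1ccco1` has not yet been measured in this assay. Within the data shown here, it differs from compound 1 in one place: furan-2-yl in place of 4-fluorophenyl on a carbon with a double bond to nitrogen The only measured step, from compound 1 to compound 2, also exchanges one aryl group for another on the carbon with a double bond to nitrogen, and it produced no change beyond the scatter. Among the measured compounds shown here, no measured step involves furan-2-yl, so the data point in no particular direction. Compound 3 is therefore expected to stay close to compound 1, with the step of a 1.2-fold higher number from compound 1 to compound 3 (0.09 log units; within the scatter) estimated to fall within the scatter. The estimate for compound 3 in this assay is 15000 nM, within a range of 5000 nM to 45000 nM.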

Compound 3, half-maximal inhibitory concentration: 12500 nM
The estimate for compound 3 lay 1.2-fold (0.08 log units) above the measured number, within the range that was stated.
By their numbers in this assay, from the lowest: compounds 1, 3 and 2 (each within the scatter of the next).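

Among these compounds, until now, the only groups seen on the carbon with a double bond to nitrogen were substituted six-membered carbon rings. Furan-2-yl differs from both: it is a five-membered aromatic ring with 1 hetero atom, has 5 heavy atoms rather than the 7 of 4-fluorophenyl, and counts 1 hydrogen-bond acceptor where 4-fluorophenyl counts 0. Yet in this assay this change leaves the number essentially where it was (a 1.0-fold higher number from compound 1 to compound 3 (0.01 log units; within the scatter)), and the exchange of 2-nitrophenyl for furan-2-yl also stays within the scatter (a 2.0-fold lower number from compound 2 to compound 3 (0.30 log units; within the scatter)), so at this place all three aromatic groups give numbers that cannot be told apart, and nothing available explains why.

Going by these compounds, all three compounds still carry an aromatic ring at this place, so it remains open whether an open propyl chain there, or a ring bearing an amine or a carboxylic acid, would move the number beyond the scatter. The rest of the shared core is identical in all three compounds, which leaves the effect of any change elsewhere on the molecule unknown.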